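The compounds below may be only part of what the source reports. "The series", "measured", "known", "first", "only" and "open" are said of these compounds alone.

Measured so far in a functional assay on the whole organism (strain albino) for inhibition, with Rattus norvegicus as the target, read by paw edema, with stated times of 30 min and 5 h, at a dose of 0.28 mmol/kg by the oral route; a lower number here means less inhibition, a higher number more inhibition at the dose given (going by the name of the read-out):
Compound 1, `C=CCn1c(SCC(=O)Nc2ccc(C(C)=O)cc2)nnc1-c1ccccc1`: 63%
Compound 2, `COc1cc(-c2nnc(SCC(=O)Nc3ccc(/C(C)=N/O)cc3)n2-c2ccccc2)cc(OC)c1OC`: 70%

Both compounds share the thioacetamide linker to an anilide, and both were tested at the same oral dose for paw edema. Compound 1 gives 63%, and compound 2 gives 70%. The two numbers lie within the usual scatter of each other, so neither compound stands apart from the other on this assay.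

Compound 3, `C=CCn1c(SCC(=O)Nc2ccc(/C(C)=N/O)cc2)nnc1-c1ccccc1`, keeps the core of compound 1 and changes only the group on the anilide ring: a group of 4 heavy atoms (2 carbon, 1 nitrogen, 1 oxygen; no ring) in place of a group of 3 heavy atoms (2 carbon, 1 oxygen; no ring), on an aromatic carbon. Among the compounds with values here, no pair of measured compounds shows this one change alone, so the data give no measured step for it; compound 2 carries the entering group, but on a different core. Compound 3 is therefore expected to land close to compound 1, with an estimated step of a number 2 percentage points higher from compound 1 to compound 3 (within the scatter), within the scatter. The estimate for compound 3 in this assay is 65%, with a range from 50% to 80%.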

Compound 3, a percentage reported as inhibition, in the whole organism at one dose (the size of the read-out at that dose, not a potency): 71%
Compound 3: middle estimate off by 6 percentage points, on the low side; the measured number falls inside the stated range.
By their numbers in this assay, from the lowest: compounds 1, 2 and 3 (each within the scatter of the next).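

Within the data shown here, compound 1 and compound 3 form the first measured pair that differs only at this position, an aromatic carbon para to a large group. In this assay, replacing acetyl with the new group gives a number 8 percentage points higher from compound 1 to compound 3 (within the scatter), so inhibition at this dose holds up even though the entering group has 1 hydrogen-bond donor and acetyl has 0. No measurement shown here accounts for this result.

The compounds shown leave open whether a quite different group at this position, such as a carboxylic acid or an amine, would also keep inhibition in this range. Because all the readings come from a single dose, they also leave open whether compound 1 and compound 3 would separate at lower doses, or whether the same swap would behave alike on the core of compound 2.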